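A Methyl Step Repeated on a Weakly Cytotoxic Scaffold

The source may hold more compounds than are shown below. What is called first, only, known or untested is meant among the compounds shown, and "the series" means these compounds.

Compound 1 `Nc1nc(-c2ccc(Br)cc2)cn1/N=C/c1cc2ccccc2nc1Cl` and compound 2 `Cc1ccc2nc(Cl)c(/C=N/n3cc(-c4ccc(Br)cc4)nc3N)cc2c1` share one core and differ by methyl in place of hydrogen on an aromatic carbon. In an ADME assay on HUVEC cells (Homo sapiens) for cytotoxicity, read by MTT assay, with a stated time of 48 h (on this read-out lower numbers stand for stronger inhibition and higher numbers for weaker inhibition), compound 1 gives 11900 nM, and compound 2 gives 13400 nM; the step is a 1.1-fold higher number from compound 1 to compound 2 (0.05 log units; within the scatter). Compound 3 `Nc1nc(-c2cccc3ccccc23)cn1/N=C/c1cc2ccccc2nc1Cl` carries another aryl group on the imidazole; the difference between its core and the core of compound 1 is not broken down here. In this assay compound 3 reaches only the limit of the assay, > 50000 nM. Compound 4 `Cc1ccc2nc(Cl)c(/C=N/n3cc(-c4cccc5ccccc45)nc3N)cc2c1` has not yet been measured and differs from compound 3 by methyl in place of hydrogen on an aromatic carbon, the same change that turned compound 1 into compound 2, at a place described in the same words. Because the measured step was a 1.1-fold higher number from compound 1 to compound 2 (0.05 log units; within the scatter), and because compound 3 already sits at the limit (the limit of > 50000 nM in this assay, at which 1 of the 3 values shown sits), the methyl is not expected to move the read-out far. The step is expected to be a step that the limit leaves unreadable from compound 3 to compound 4. Compound 4 is therefore estimated at 60000 nM, with a range from 30000 nM to 150000 nM, most likely reported again only as a limit.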

Compound 4, half-maximal inhibitory concentration: 9580 nM
Estimate against measurement, compound 4: 6.3-fold (0.80 log units) above; the whole stated range lies above it.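

In this assay, with naphthalen-1-yl in place of 4-bromophenyl, the methyl change gives an at least 5.2-fold lower number from compound 3 to compound 4 (0.71 log units; beyond the scatter), while the aryl exchange with the methyl already in place gives a 1.4-fold lower number from compound 2 to compound 4 (0.15 log units; within the scatter), a step within the scatter. Set side by side, the two methyl steps differ: the same change on two cores in this assay, a 1.1-fold higher number (0.05 log units; within the scatter) from compound 1 to compound 2 and an at least 5.2-fold lower number (0.71 log units; beyond the scatter) from compound 3 to compound 4, at least 5.8-fold (0.76 log units) apart, beyond the scatter of two such steps. Going by these compounds alone, this shows that the size of the methyl step cannot simply be carried from one core to the other, but it rests on only two pairs, the value of compound 3 is a limit and not a number, so the true size of its step remains unknown, and nothing here shows why the two steps differ.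

The compounds shown leave open whether a methoxy group, a chlorine atom or an ethyl chain at the same aromatic carbon would also separate the two cores. They also leave open how the methyl step behaves with aryl groups other than 4-bromophenyl and naphthalen-1-yl.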